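The source may hold more compounds than are shown below. What is called first, only, known or untested is meant among the compounds shown, and "the series" means these compounds.

For the measured compounds named here, in a functional assay on MCF7 cells (Homo sapiens) for antiproliferative activity, read by MTT assay, with a stated time of 48 h (on this read-out lower numbers stand for stronger inhibition and higher numbers for weaker inhibition), compound 3 `CSC(=S)OC/C1=C/C[C@](C)(CCC=C(C)C)/C=C/[C@@H](OC(=O)C=C(C)C)[C@](C)(O)/C=C/C1=O` gives 900 nM, the second highest of the three numbers so far. Compound 1 `CC(C)=CCC[C@]1(C)/C=C/[C@@H](OC(=O)C=C(C)C)[C@](C)(O)/C=C/C(=O)/C(C=O)=C\C1` gives 12600 nM, and compound 2 `CC(C)=CCC[C@]1(C)/C=C/[C@@H](OC(=O)C=C(C)C)[C@](C)(O)/C=C/C(=O)/C(CN2CCCC2)=C\C1` gives 220 nM. Compound 4 `CC(C)=CCC[C@]1(C)/C=C/[C@@H](OC(=O)C=C(C)C)[C@](C)(O)/C=C/C(=O)/C(C(=O)N(C)C)=C\C1` is still unmeasured and carries dimethylcarbamoyl on a double-bonded ring carbon of the shared core: a group of 5 heavy atoms (3 carbon, 1 nitrogen, 1 oxygen; no ring) in place of a group of 6 heavy atoms (3 carbon, 1 oxygen, 2 sulfur; no ring), on a double-bonded ring carbon.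

Going by the values given here, three measured steps bear on this change. Both replacements of formyl were large: a 57-fold lower number from compound 1 to compound 2 (1.76 log units; beyond the scatter), and a 14-fold lower number from compound 1 to compound 3 (1.15 log units; beyond the scatter). The gap between the two replacements is modest: a 4.1-fold higher number from compound 2 to compound 3 (0.61 log units; beyond the scatter). In compounds 2 and 3 a saturated chain carbon is bound to the double-bonded ring carbon, whereas in compound 1 and compound 4 a carbonyl sits on that ring carbon. No amide has been measured in this series, so the closest guide is uncertain.

A modest move towards a higher number is therefore expected in this assay, with the result expected to remain lower than the number for compound 1, which gives 12600 nM. The expected step is a 2.8-fold higher number from compound 3 to compound 4 (0.44 log units; beyond the scatter). Compound 4 is estimated at 2500 nM, with an expected range of 700 nM to 9000 nM.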

Compound 4, half-maximal inhibitory concentration: 3670 nM
Beside the measured number, compound 4's estimate is 1.5-fold (0.17 log units) below it; measured number inside the range.
By their numbers in this assay, from the lowest: compound 2; then compound 3; then compound 4; then compound 1.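

In this assay, dimethylcarbamoyl shows that a carbonyl on the double-bonded ring carbon can go with a lower number than formyl, though the change is only modest: a 3.4-fold lower number from compound 1 to compound 4 (0.54 log units; beyond the scatter). Compound 4 also stands clearly higher than both compounds with a saturated chain carbon on that ring carbon, with a 4.1-fold higher number from compound 3 to compound 4 (0.61 log units; beyond the scatter) and a 17-fold higher number from compound 2 to compound 4 (1.22 log units; beyond the scatter), so among these four compounds the two carrying a carbonyl there give the two highest numbers, and none goes against this order. No measurement at hand accounts for this order.

On these data alone, whether the order holds for other carbonyl groups on this ring carbon remains open, for example a carboxylic acid, its methyl ester or an amide that keeps the amide hydrogen. As far as these compounds go, it is also open whether the low number of compound 2 needs the pyrrolidine ring or persists with an open-chain amine such as dimethylaminomethyl on the same ring carbon.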